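The source may hold more compounds than are shown below. What is called first, only, known or untested is meant among the compounds shown, and "the series" means these compounds.

Compound 1 `COc1cccc(/C=N/Nc2ncc3c(n2)n(C2CCCC2)c(=O)c(=O)n3C)c1` is studied in a functional assay on A549 cells (Homo sapiens) for antiproliferative activity, read by MTT assay (on this read-out higher numbers stand for weaker inhibition and lower numbers for stronger inhibition), where compound 1 gives 27400 nM, the higher of the two numbers measured. Compound 2 `Cn1c(=O)c(=O)n(C2CCCC2)c2nc(N/N=C/c3cc(C(F)(F)F)cc(C(F)(F)F)c3)ncc21` gives 3230 nM in this assay, a gap beyond the scatter. Compound 3 `Cn1c(=O)c(=O)n(C2CCCC2)c2nc(N/N=C/c3ccc(F)cc3Br)ncc21` has not yet been measured in this assay. It differs from compound 1 by 2-bromo-4-fluorophenyl in place of 3-methoxyphenyl on a carbon with a double bond to nitrogen. Among the compounds with values here, no measured pair shows this change, so the step is estimated from the two compounds alone. Compound 3 is expected to show a moderate downward step a 2.7-fold lower number from compound 1 to compound 3 (0.44 log units; beyond the scatter), since compound 2 gives 3230 nM. Compound 3 is therefore estimated at 10000 nM, within 3000 nM to 30000 nM.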

Compound 3, half-maximal inhibitory concentration: 6590 nM
Beside the measured number, compound 3's estimate is 1.5-fold (0.18 log units) above it; low and high end bracket the measured number.
By their numbers in this assay, from the lowest: compound 2; then compound 3; then compound 1.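

Placing 2-bromo-4-fluorophenyl in place of 3-methoxyphenyl on the carbon with a double bond to nitrogen gives a 4.2-fold lower number from compound 1 to compound 3 (0.62 log units; beyond the scatter) in this assay, a modest step beyond the scatter. The number falls even though the entering group has no hydrogen-bond acceptor, so compound 3 does not need the acceptor of compound 1 at this position to reach its level of inhibition. Nothing available explains this step. Bromine and fluorine enter together, so their separate shares remain open. Going by these compounds, how a phenyl ring carrying an amine or a carboxylic acid would read at this position also remains open.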